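The source may report more compounds than this note shows. Statements on the series, on what has been measured and on what is new or still open speak of the compounds shown alone.

Compound 1 `Cc1c(C(=O)N/N=C\c2ccccc2O)oc2cccc(O)c12`: 8350 nM
Compound 2 `Cc1c(C(=O)N/N=C\c2cccc(F)c2)oc2cccc(O)c12`: >= 40000 nM

In a functional assay on PC-3 cells (Homo sapiens) for inhibition (on this read-out higher numbers stand for weaker inhibition and lower numbers for stronger inhibition), compound 1 gives 8350 nM, the only number shown. Compound 2 reaches only a limit of the assay, >= 40000 nM, the one limit shown here (the limit of >= 40000 nM in this assay, at which 1 of the 2 values shown sits). Compound 3 `Cc1c(C(=O)N/N=C\c2c(O)cccc2Cl)oc2cccc(O)c12` differs from compound 1 by chloro in place of hydrogen on an aromatic carbon, so that 2-hydroxyphenyl becomes 2-chloro-6-hydroxyphenyl. For the measured compounds named here, the one measured step, an at least 4.7-fold higher number from compound 1 to compound 2 (0.68 log units; beyond the scatter), removed the hydroxy group entirely and is therefore only a loose guide; compound 3 keeps that group. No change beyond the scatter is expected, a 1.0-fold lower number from compound 1 to compound 3 (0.02 log units; within the scatter). Compound 3 is estimated at 8000 nM, between 3000 nM and 25000 nM.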

Compound 3, half-maximal inhibitory concentration: 18700 nM
Compound 3: middle estimate off by 2.3-fold (0.37 log units), on the low side, and the stated range covers the measured number.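

Chloro in place of hydrogen on this aromatic carbon, ortho to a large group and meta to a hydroxy group, is not a silent change, giving a 2.2-fold higher number from compound 1 to compound 3 (0.35 log units; beyond the scatter). Even so, inhibition stays measurable with the hydroxy group kept, at an at least 2.1-fold lower number from compound 2 to compound 3 (0.33 log units; beyond the scatter). That step is read against a limit and not against a number: the limit of >= 40000 nM in this assay, at which 1 of the 3 values shown sits.

The compounds shown leave open whether a methyl or a methoxy group on the same carbon would move the number as chloro does. They also leave open whether the hydroxy group alone separates compound 1 from compound 2.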